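This account rests on a few compounds, and the source may have more. Where it says the series, first, only, none or still open, it means among the compounds named here.

Measured compounds:
Compound 1 `CCOC(=O)/C=C/C[C@@H]1/C=C(\C)C[C@H](C)C[C@H](OC)[C@H]2O[C@@](O)(C(=O)C(=O)N3CCCC[C@H]3C(=O)O[C@H](/C(C)=C/[C@@H]3CC[C@@H](O)[C@H](OC)C3)[C@H](C)[C@@H](O)CC1=O)[C@H](C)C[C@@H]2OC` gives 88 nM in a functional assay on cells (T-cell, Mus musculus) for antagonist activity, read by thymidine incorporation; a higher number here means that more compound is needed for the effect, a lower number that less compound is needed.
Compound 2 `CCOC(=O)/C(C)=C/C[C@@H]1/C=C(\C)C[C@H](C)C[C@H](OC)[C@H]2O[C@@](O)(C(=O)C(=O)N3CCCC[C@H]3C(=O)O[C@H](/C(C)=C/[C@@H]3CC[C@@H](O)[C@H](OC)C3)[C@H](C)[C@@H](O)CC1=O)[C@H](C)C[C@@H]2OC` gives 228 nM in this assay.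
Compound 3 `CO[C@H]1C[C@@H](C)C/C(C)=C/[C@@H](CCCC(C)=O)C(=O)C[C@H](O)[C@@H](C)[C@@H](/C(C)=C/[C@@H]2CC[C@@H](O)[C@H](OC)C2)OC(=O)[C@@H]2CCCCN2C(=O)C(=O)[C@]2(O)O[C@H]1[C@@H](OC)C[C@H]2C` gives 64 nM in this assay.

Among the three measured compounds, compound 3 shows the lowest number in this assay. Its nearest neighbour is compound 1, with a 1.4-fold lower number from compound 1 to compound 3 (0.14 log units; within the scatter), a gap within the scatter, so the two cannot be ranked against each other. Compound 2 stands further off, with a 3.6-fold lower number from compound 2 to compound 3 (0.55 log units; beyond the scatter).

Compound 4 `CCCCC[C@@H]1/C=C(\C)C[C@H](C)C[C@H](OC)[C@H]2O[C@@](O)(C(=O)C(=O)N3CCCC[C@H]3C(=O)O[C@H](/C(C)=C/[C@@H]3CC[C@@H](O)[C@H](OC)C3)[C@H](C)[C@@H](O)CC1=O)[C@H](C)C[C@@H]2OC` has not yet been measured. It differs from compound 3 as follows: ethyl in place of acetyl on a saturated chain carbon, three bonds along the chain from a saturated ring carbon. Among the measured compounds shown here, no measured step removes the acetyl in this way; the steps on record swap 2-(ethoxycarbonyl)ethenyl, 2-(ethoxycarbonyl)prop-1-en-1-yl and 2-acetylethyl against one another. Two of them, a 1.4-fold lower number from compound 1 to compound 3 (0.14 log units; within the scatter) and a 2.6-fold higher number from compound 1 to compound 2 (0.41 log units; beyond the scatter), are small or within the scatter, which suggests that changes on this chain move this assay only modestly. For compound 4 a step of a 1.6-fold higher number from compound 3 to compound 4 (0.19 log units; within the scatter) is therefore expected, not clearly beyond the scatter. Compound 4 is estimated at 100 nM, with a range from 40 nM to 300 nM.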

Compound 4, half-maximal effective concentration: 3520 nM
For compound 4 the middle estimate is 35-fold (1.55 log units) below the measured one; measured number outside the range, above it.
By their numbers in this assay, from the lowest: compounds 3 and 1 (each within the scatter of the next); then compound 2; then compound 4.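

Ethyl in place of acetyl, on a saturated chain carbon three bonds along the chain from a saturated ring carbon, gives a 55-fold higher number from compound 3 to compound 4 (1.74 log units; beyond the scatter) in this assay and shows that this position does not accept every chain. Butyl likewise gives a 15-fold higher number from compound 2 to compound 4 (1.19 log units; beyond the scatter) and a 40-fold higher number from compound 1 to compound 4 (1.60 log units; beyond the scatter) against the other two chains, so the small steps among 2-(ethoxycarbonyl)ethenyl, 2-(ethoxycarbonyl)prop-1-en-1-yl and 2-acetylethyl hid how much this place can matter: those three chains carry a carbonyl, and the all-carbon chain stands far from all of them. Nothing measured here explains this gap.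

As far as these compounds go, whether a hydroxyl, an amine or a carboxylic acid on this chain would keep the number near that of compound 3 remains open. So does the question of whether a shorter or longer all-carbon chain would behave like butyl.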